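Swapping Nitro for Bromo in a Well-Tolerated Compound

A few compounds are considered here, and "the series" means these few. Any claim that something is new, unique, unknown or untested is made for them only; others in the source may bear on it.

Among the measured compounds shown here, in an ADME assay on MT4 cells (Homo sapiens) for cytotoxicity, read by MTT assay, with a stated time of 96 h (a higher number here means that more compound is tolerated, a lower number that less compound is tolerated), compound 1 (`Cc1ccc(/N=N/c2ccc(NCCCN(C)C)cc2)cc1`) gives 17000 nM as the only measured number so far. Compound 2 (`O=[N+]([O-])c1ccc(/N=N/N2CCCC2)cc1`) stands at >= 100000 nM as a limit of the assay and not a number. Compound 3 (`CN1CCN(/N=N/c2cc(F)ccc2F)CC1`) also stands at a limit of the assay, > 100000 nM in this case.

Compound 4 (`Brc1ccc(/N=N/N2CCCC2)cc1`) has not yet been measured. It carries bromo in place of nitro on an aromatic carbon. For the measured compounds named here, no two measured compounds differ in one place, so no measured step shows how large this change should be. In this assay a modest step toward a lower number is expected, or none beyond the usual scatter, because compound 1 gives 17000 nM and so shows that lower numbers do occur in this small set. The estimated change is an at least 1.4-fold lower number from compound 2 to compound 4 (0.15 log units; that floor lies within the scatter) on this reasoning. Compound 4 is estimated at 70000 nM with an expected range from 20000 nM to 100000 nM for its measurement.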

Compound 4, half-maximal cytotoxic concentration: > 100000 nM
Compound 4: no number, only a limit; the forecaster's own chance of this, stated with the estimate: 50%; at least 1.4-fold (0.15 log units) between middle value and limit.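

Compound 2 and compound 4 both stand at a limit of this assay and not at a number, so the step between them cannot be read. From the compounds shown here alone, whether bromo in place of nitro changes the tolerated concentration at all, and in which direction, stays open.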